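The source may hold more compounds than are shown below. What is called first, only, known or untested is meant among the compounds shown, and "the series" means these compounds.

Measured so far in a functional assay on LoVo cells (Homo sapiens) for inhibition, read by MTT assay, with a stated time of 24 h; a lower number here means a stronger inhibitor, a higher number a weaker inhibitor:
- compound 1 `CC1(C)[C@H]2CC[C@]1(C)N(Cc1cn(-c3ccc(Cl)cc3)nn1)C(=O)C2`: compound 1 gives 160 nM
- compound 2 `Cc1ccccc1-n1cc(CN2C(=O)C[C@@H]3CC[C@@]2(C)C3(C)C)nn1`: compound 2 gives 80 nM
- compound 3 `CC1(C)[C@H]2CC[C@]1(C)N(Cc1cn(-c3ccccc3Br)nn1)C(=O)C2`: compound 3 gives 60 nM

All three compounds share one core and differ only in the substituted phenyl carried on an aromatic nitrogen. Compound 1 has the highest number of the three: the step to compound 2 is a 2.0-fold lower number from compound 1 to compound 2 (0.30 log units; within the scatter), and the step to compound 3 is a 2.7-fold lower number from compound 1 to compound 3 (0.43 log units; beyond the scatter). Between the other two, a 1.3-fold lower number from compound 2 to compound 3 (0.12 log units; within the scatter).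

Compound 4 `CC1(C)[C@H]2CC[C@]1(C)N(Cc1cn(-c3ccc(F)cc3)nn1)C(=O)C2` keeps everything of compound 1 except one atom: fluoro in place of chloro on an aromatic carbon. None of the three measured steps exchanges one halogen for another; each instead changes the whole substituted phenyl, and the largest of them, a 2.7-fold lower number from compound 1 to compound 3 (0.43 log units; beyond the scatter), is only modest. Within the data shown here, no measured step therefore bears directly on this change, and nothing here points to a shift beyond the scatter in this assay in either direction.

Compound 4 is expected to give about 200 nM, with a range from 90 nM to 450 nM. This estimate means an expected step of a 1.3-fold higher number from compound 1 to compound 4 (0.10 log units; within the scatter), which stays within the scatter.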

Compound 4, half-maximal inhibitory concentration: 40 nM
Beside the measured number, compound 4's estimate is 5.0-fold (0.70 log units) above it, and the stated range ends above it.
By their numbers in this assay, from the lowest: compounds 4, 3, 2 and 1 (each within the scatter of the next, the first and the last beyond it).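

In this assay the change from 4-chlorophenyl to 4-fluorophenyl gives a 4.0-fold lower number from compound 1 to compound 4 (0.60 log units; beyond the scatter) as a modest step, the largest shown so far. Among these compounds, the earlier steps all replaced the whole substituted phenyl, so this is the first sign that one halogen atom alone, on this aromatic carbon, can move the number beyond the scatter. Yet a 1.5-fold lower number from compound 3 to compound 4 (0.18 log units; within the scatter) and a 2.0-fold lower number from compound 2 to compound 4 (0.30 log units; within the scatter) both stay within the scatter, so the 4-fluorophenyl, 2-bromophenyl and 2-methylphenyl compounds cannot be ranked against one another.

Nothing given here explains why fluoro and chloro differ in this way. Also open, going by these compounds, is how this position would respond to a bromo or methoxy group or an amine, and whether a plain phenyl, with hydrogen there, would sit nearer compound 4 or compound 1.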